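The source may hold more compounds than are shown below. What is called first, only, known or untested is meant among the compounds shown, and "the series" means these compounds.

Measured in a functional assay on HepG2 cells (Homo sapiens) for inhibition, read by MTT assay, with a stated time of 72 h; a higher number here means a weaker inhibitor, a lower number a stronger inhibitor:
- compound 1 `Nc1ncnc2c1c(-c1cnc3[nH]ccc3c1)nn2CCCCC(=O)NO`: 36700 nM
- compound 2 `Nc1ncnc2c1c(-c1cnc3[nH]ccc3c1)nn2CCCCCCCCCC(=O)NO`: 11700 nM
- compound 3 `Nc1ncnc2c1c(-c1cnc3[nH]ccc3c1)nn2CCCCCCC(=O)NO`: 10300 nM

Compound 3 sits at the low end of these numbers, a place it shares with one other chain. The gap there is small: a 1.1-fold lower number from compound 2 to compound 3 (0.06 log units; within the scatter). The larger gaps belong to the short chain: a 3.6-fold lower number from compound 1 to compound 3 (0.55 log units; beyond the scatter), and a 3.1-fold lower number from compound 1 to compound 2 (0.50 log units; beyond the scatter).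

Next is compound 4 `Nc1ncnc2c1c(-c1cnc3[nH]ccc3c1)nn2CCCC(=O)NO`, with the chain cut back: hydroxycarbamoyl in place of 3-(hydroxycarbamoyl)propyl on a saturated chain carbon, three bonds along the chain from an aromatic nitrogen, three bonds along the chain from an aromatic nitrogen.

The closest evidence is a 3.6-fold lower number from compound 1 to compound 3 (0.55 log units; beyond the scatter), read in reverse, since compound 1 carries the chain nearest to that of compound 4. A higher number of about that size is therefore expected in this assay: a 3.7-fold higher number from compound 3 to compound 4 (0.57 log units; beyond the scatter). For compound 4 the estimated value is 38000 nM, with an expected range of 15000 nM to 90000 nM.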

Compound 4, half-maximal inhibitory concentration: > 50000 nM
Compound 4 gave a limit, no number; the forecaster's own chance of this, stated with the estimate: 20%; at least 1.3-fold (0.11 log units) between middle value and limit.
By their numbers in this assay, from the lowest: compounds 3 and 2 (each within the scatter of the next); then compound 1. At a limit, above all of these: compound 4.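

In this assay compound 4 gives only a limit, > 50000 nM. Hydroxycarbamoyl in place of 3-(hydroxycarbamoyl)propyl on a saturated chain carbon, three bonds along the chain from an aromatic nitrogen, gives an at least 4.8-fold higher number from compound 3 to compound 4 (0.68 log units; beyond the scatter). Hydroxycarbamoyl in place of 6-(hydroxycarbamoyl)hexyl at that place gives an at least 4.2-fold higher number from compound 2 to compound 4 (0.63 log units; beyond the scatter). Hydroxycarbamoyl in place of (hydroxycarbamoyl)methyl at that place gives an at least 1.3-fold higher number from compound 1 to compound 4 (0.13 log units; that floor lies within the scatter), so the data do not separate the two shortest chains.

From the compounds shown here alone, it remains open whether a carboxylic acid or an amine in place of hydroxycarbamoyl would keep the numbers of compound 3 and compound 2. A longer chain than that of compound 2 is also untested in the compounds shown.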